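A propyl group added to the anilino ring of compound 2

The compounds below may be only part of what the source reports. "The series", "measured", "known", "first", "only" and "open" are said of these compounds alone.

Compound 2 `O=C1C(Nc2ccccc2)=CC(=O)c2c1nc1n2[C@H]2OC[C@@H](O)[C@H]2OC1` gives the lowest of the two numbers shown: in a functional assay on MGC-803 cells (Homo sapiens) for inhibition, read by sulforhodamine B assay (on this read-out higher numbers stand for weaker inhibition and lower numbers for stronger inhibition), compound 2 gives 1830 nM. Compound 1 `O=C1C=C(NCc2ccccc2)C(=O)c2c1nc1n2[C@H]2OC[C@@H](O)[C@H]2OC1` gives 2670 nM, which lies within the scatter of compound 2. Compound 3 `CCCN(CCC)C1=CC(=O)c2nc3n(c2C1=O)[C@H]1OC[C@@H](O)[C@H]1OC3` reaches only a limit of this assay, > 16000 nM. Among the compounds with values here, the one measured step, an at least 5.9-fold higher number from compound 1 to compound 3 (0.77 log units; beyond the scatter), swaps the whole amine substituent and so does not directly test a change on the phenyl ring. Compound 4 `CCCc1ccc(NC2=CC(=O)c3c(nc4n3[C@H]3OC[C@@H](O)[C@H]3OC4)C2=O)cc1` differs from compound 2 by propyl in place of hydrogen on an aromatic carbon, turning phenyl into 4-propylphenyl. Within the data shown here, with no measured step of this kind, the change is expected to stay within the scatter, a 1.0-fold lower number from compound 2 to compound 4 (0.01 log units; within the scatter). Compound 4 is therefore estimated at 1800 nM, expected between 700 nM and 5000 nM.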

Compound 4, half-maximal inhibitory concentration: 1920 nM
The estimate for compound 4 lay 1.1-fold (0.03 log units) below the measured number; low and high end bracket the measured number.
By their numbers in this assay, from the lowest: compounds 2, 4 and 1 (each within the scatter of the next). At a limit, above all of these: compound 3.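

In this assay, 4-propylphenyl in place of phenyl gives a 1.0-fold higher number from compound 2 to compound 4 (0.02 log units; within the scatter) and so leaves the number effectively unchanged. The earlier step swapped the whole amine substituent, whereas this one alters only the aromatic ring, and it shows that this position can carry a propyl group without a readable loss of inhibition. Nothing in the data shown explains this outcome.

On these data alone, whether a longer chain, an amine or a carboxylic acid at the same place would also leave the number unchanged remains open. So does whether propyl would act the same way on the benzylamino group of compound 1.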